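A few compounds are considered here, and "the series" means these few. Any claim that something is new, unique, unknown or untested is made for them only; others in the source may bear on it.

Compound 1 `CNC(=O)c1cc(C(=O)NC2CC2)cn(Cc2cccc(OC)c2)c1=O` is one of three compounds examined in a physicochemical assay for solubility (on this read-out higher numbers stand for higher solubility and lower numbers for lower solubility), and in this assay compound 1 gives 79 ug/mL. Among the measured compounds shown here, this is the only plain number among the three: the other two readings stop at a limit of the assay. Compound 2 `CNC(=O)c1cc(C(=O)NC2CCC2)cn(Cc2cccnc2)c1=O` reaches only such a limit, >= 99 ug/mL, in this assay. Compound 3 `CNC(=O)c1cc(C(=O)NCCOC)cn(Cc2ccccc2)c1=O` likewise reports only a limit, >= 164 ug/mL, in this assay. So compound 1 stands below the limit of >= 164 ug/mL in this assay, at which 1 of the 3 values shown sits, and below (the limit of >= 99 ug/mL in this assay, at which 1 of the 3 values shown sits), each of which one other compound reaches, and it is the sole fixed point against which a new compound can be set.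

Compound 4 `CNC(=O)c1cc(C(=O)NC2CC2)cn(Cc2cccc3[nH]ncc23)c1=O` has not yet been measured. It differs from compound 1 in one place: 1H-indazol-4-yl in place of 3-methoxyphenyl on a saturated chain carbon bound to an aromatic nitrogen. For the measured compounds named here, no measured pair shows a change of this kind, so the size of its effect cannot be read from the data; a modest downward step from compound 1 to compound 4 in this assay is expected, of the order of a 1.8-fold lower number from compound 1 to compound 4 (0.24 log units; within the scatter), though a result within the usual scatter would not be surprising. Compound 4 is therefore estimated at 45 ug/mL in this assay, with a likely range from 15 ug/mL to 130 ug/mL.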

Compound 4, solubility: 10 ug/mL
Compound 4: the middle estimate sits 4.5-fold (0.65 log units) above what was measured, and the stated range ends above it.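

In this assay, putting 1H-indazol-4-yl in place of 3-methoxyphenyl on a saturated chain carbon bound to an aromatic nitrogen gives a 7.9-fold lower number from compound 1 to compound 4 (0.90 log units; beyond the scatter). This is the first step shown at this place, and it reveals that swapping one aromatic group for another here can move the read-out beyond ordinary scatter. The entering group brings a five-membered aromatic ring with 2 hetero atoms and 1 hydrogen-bond donor, but no measurement shown explains the step, and compounds 2 and 3 each differ from compound 1 in more than one place.

The compounds shown do not separate the part played by the added ring from that of the hydrogen-bond donor. From the compounds shown here alone, how this assay would respond to an amine or a carboxylic acid in place of the methoxy group of 3-methoxyphenyl also remains open.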